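Two Measured Compounds and an Expected Cytotoxicity Value

The compounds below may be only part of what the source reports. "The series", "measured", "known", "first", "only" and "open" are said of these compounds alone.

compound 1 `Cc1ccc(C(=O)N(C(=S)OCCN2C(=O)c3ccccc3C2=O)c2ccc(Cl)cc2)cc1` — > 100000 nM
compound 2 `Cc1ccc(N(C(=O)c2ccccc2[N+](=O)[O-])C(=S)OCCN2C(=O)c3ccccc3C2=O)cc1` — 100000 nM

Both were tested in an ADME assay on MT4 cells (Homo sapiens) for cytotoxicity, read by MTT assay; on this read-out higher numbers stand for lower toxicity in this test and lower numbers for higher toxicity in this test. For compound 1 the value > 100000 nM is a limit of the assay, not a number. Compound 2 gives 100000 nM in this assay. Compound 3 `O=C1c2ccccc2C(=O)N1CCOC(=S)N(C(=O)c1ccc(Cl)c([N+](=O)[O-])c1)c1ccc(Cl)cc1` differs from compound 1 by 4-chloro-3-nitrophenyl in place of 4-methylphenyl on a carbonyl carbon. Going by the values given here, no step between measured compounds is available, so the expectation rests on the structural change alone and on compound 1 standing at the limit (the limit of > 100000 nM in this assay, at which 1 of the 2 values shown sits). In this assay the expected step is a number no higher from compound 1 to compound 3 (the limit leaves the size open), none beyond the scatter. Compound 3 is estimated at 100000 nM, between 40000 nM and 300000 nM.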

Compound 3, half-maximal cytotoxic concentration: 48000 nM
Estimate against measurement, compound 3: 2.1-fold (0.32 log units) above; the measured number falls inside the stated range.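

In this assay, this position on the carbonyl carbon turns out to respond to substitution: 4-chloro-3-nitrophenyl in place of 4-methylphenyl gives an at least 2.0-fold lower number from compound 1 to compound 3 (0.31 log units; beyond the scatter). Going by these compounds alone, this is the first step read at this position, and its direction is clear, with the number moving towards higher toxicity in this test. Its full size stays unknown, as compound 1 stands at a limit of the assay: the limit of > 100000 nM in this assay, at which 1 of the 3 values shown sits.

The compounds shown leave open whether the chloro or the nitro part of the entering group carries this step. They also leave open how an amine or a carboxylic acid on this ring would read.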